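The source may hold more compounds than are shown below. What is called first, only, known or untested is meant among the compounds shown, and "the series" means these compounds.

Measured so far:
- compound 1, `CNC(=O)c1cc(C(=O)NC2CC2)c(C)n(Cc2ccccc2)c1=O`: in a physicochemical assay for solubility (on this read-out lower numbers stand for lower solubility and higher numbers for higher solubility), compound 1 gives >= 126 ug/mL, which is a limit of the measurement and not a number.
- compound 2, `CNC(=O)c1cc(C(=O)NC2CC2)cn(Cc2nccc3[nH]ccc23)c1=O`: compound 2 gives 73 ug/mL.
- compound 3, `CNC(=O)c1cc(C(=O)NCCC(C)C)cn(Cc2ccccc2)c1=O`: compound 3 gives 10 ug/mL.

Compound 2 holds the highest of the two numbers read in this assay. Its nearest neighbour is compound 3, whose value lies well beyond the scatter below that of compound 2. Compound 1 stands apart in that its reading is only a limit (the limit of >= 126 ug/mL in this assay, at which 1 of the 3 values shown sits). Among the compounds with values here, no pair among the measured compounds differs in a single place, so no measured step is available.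

The next compound is compound 4, `CNC(=O)c1cc(C(=O)NC2CC2)cn(Cc2ccccc2F)c1=O`, not yet measured in this assay. It is derived from compound 2 by the change (a group of 7 heavy atoms (6 carbon, 1 fluorine; one six-membered aromatic ring of carbon only) in place of a group of 9 heavy atoms (7 carbon, 2 nitrogen; one five-membered aromatic ring with 1 hetero atom, one six-membered aromatic ring with 1 hetero atom), on a saturated chain carbon bound to an aromatic nitrogen).

Within the data shown here, with no measured step to lean on, the expectation for compound 4 rests on the values shown. Compound 4 is expected to give about 60 ug/mL in this assay, with a range of 20 ug/mL to 150 ug/mL. The step this estimate implies, a 1.2-fold lower number from compound 2 to compound 4 (0.09 log units; within the scatter), is expected to stay within the scatter or to be a modest fall; a reading at the assay limit cannot be excluded.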

Compound 4, solubility: >= 145 ug/mL
Compound 4: no number, only a limit; the forecaster's own chance of this, stated with the estimate: 20%; at least 2.4-fold (0.38 log units) between middle value and limit.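

In this assay compound 4 gives >= 145 ug/mL, which is a limit of the measurement and not a number: the limit of >= 145 ug/mL in this assay, at which 1 of the 4 values shown sits. Within the data shown here, with 2-fluorophenyl entering on a saturated chain carbon bound to an aromatic nitrogen, the series gains its only measured step at this place, an at least 1.9-fold higher number from compound 2 to compound 4 (0.29 log units; that floor lies within the scatter), and only a floor can be read from it, with the true size left unfixed. The group that leaves holds 1 hydrogen-bond donor and 1 hydrogen-bond acceptor and the 2-fluorophenyl group holds 0 of each, yet no fall appears on this change, although a single step ties the result to neither those counts nor any other feature of the two groups.

As far as these compounds go, the actual number for compound 4 stays open, and with it how far this step really reaches beyond its floor. Also open, from the compounds shown here alone, is how the fluorine on its own counts, which a plain phenyl at this place on the same core would address, and how an amine or a carboxylic acid on that ring would read in this assay.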